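The source may hold more compounds than are shown below. What is called first, only, known or untested is meant among the compounds shown, and "the series" means these compounds.

Compound 1 `COc1ccc(/C=N/NC(=O)Nc2ccc(Oc3ccnc(-c4nncn4CCN(C)C)c3)c(F)c2)c(OC)c1`: 12600 nM
Compound 2 `CN(C)CCn1cnnc1-c1cc(Oc2ccc(NC(=O)N/N=C/c3c(O)ccc4ccccc34)cc2F)ccn1`: 620 nM
Compound 3 `CN(C)CCn1cnnc1-c1cc(Oc2ccc(NC(=O)N/N=C/c3ccc(O)cc3)cc2F)ccn1`: 7750 nM

These three compounds share one core and differ only in the group on a carbon with a double bond to nitrogen. In a functional assay on U-87MG ATCC cells (Homo sapiens) for cytotoxicity, read by MTT assay, with a stated time of 72 h (a higher number here means a weaker inhibitor, a lower number a stronger inhibitor), compound 1 gives the highest number of the three: compound 3 sits closest, a 1.6-fold lower number from compound 1 to compound 3 (0.21 log units; within the scatter), and compound 2 furthest, a 20-fold lower number from compound 1 to compound 2 (1.31 log units; beyond the scatter). Compound 4 `CN(C)CCn1cnnc1-c1cc(Oc2ccc(NC(=O)N/N=C/c3ccc(O)c(F)c3)cc2F)ccn1` is not yet measured. Its change from compound 1 is 3-fluoro-4-hydroxyphenyl in place of 2,4-dimethoxyphenyl on a carbon with a double bond to nitrogen. The closest comparison is compound 3, whose 4-hydroxyphenyl differs from the entering 3-fluoro-4-hydroxyphenyl only by the fluorine; that step, a 1.6-fold lower number from compound 1 to compound 3 (0.21 log units; within the scatter), lay within the scatter. The large step of a 20-fold lower number from compound 1 to compound 2 (1.31 log units; beyond the scatter) involves a different group and is not expected to apply. The step expected here is a 1.8-fold lower number from compound 1 to compound 4 (0.26 log units; within the scatter), small or none beyond the scatter. Compound 4 is estimated at 7000 nM, with a range from 2500 nM to 20000 nM.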

Compound 4, half-maximal inhibitory concentration: > 100000 nM
Compound 4: only a limit was reported; the forecaster's own chance of this, stated with the estimate: 5%; middle value at least 14-fold (1.15 log units) from the limit.
By their numbers in this assay, from the lowest: compound 2; then compounds 3 and 1 (each within the scatter of the next). At a limit, above all of these: compound 4.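

Compound 4 gives only a limit of the assay, not a number: the limit of > 100000 nM in this assay, at which 1 of the 4 values shown sits.

At this position, one added fluoro on the 4-hydroxyphenyl group counts for far more than the earlier swaps suggested, with an at least 12-fold higher number from compound 3 to compound 4 (1.11 log units; beyond the scatter). The 3-fluoro-4-hydroxyphenyl group also falls behind both other groups, with an at least 7.9-fold higher number from compound 1 to compound 4 (0.89 log units; beyond the scatter) and an at least 160-fold higher number from compound 2 to compound 4 (2.20 log units; beyond the scatter), so the range at this position is wider than the first three compounds showed.

From the compounds shown here alone, whether a chloro or methyl group in place of the fluoro would behave the same stays open. Going by these compounds, the full size of these steps also stays open, since compound 4 has only a limit.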